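Ethoxy for Methylsulfanyl on a Beta-Lactam Tubulin-Type Scaffold

The compounds below may be only part of what the source reports. "The series", "measured", "known", "first", "only" and "open" are said of these compounds alone.

Measured compounds:
compound 1, `C=CC1C(=O)N(c2cc(OC)c(OC)c(OC)c2)C1c1ccc(OC)cc1`, 10 nM
compound 2, `COc1cc(N2C(=O)C(O)C2c2ccc(SC)cc2)cc(OC)c1OC`, 15 nM

In a functional assay on HT-29 cells (Homo sapiens) for inhibition, read by sulforhodamine B assay, with a stated time of 72 h (on this read-out higher numbers stand for weaker inhibition and lower numbers for stronger inhibition), compound 2 gives the higher of the two numbers, yet compound 1 at 10 nM sits within the usual scatter of it, so the two cannot be told apart. Compound 3, `CCOc1ccc(C2C(O)C(=O)N2c2cc(OC)c(OC)c(OC)c2)cc1`, is not yet measured. It differs from compound 2 in one place: ethoxy in place of methylsulfanyl on an aromatic carbon. Within the data shown here, with no measured step of this kind to lean on, the expectation from compound 2 to compound 3 is a modest weakening, a 2.7-fold higher number from compound 2 to compound 3 (0.43 log units; beyond the scatter), possibly just beyond the scatter. Compound 3 is therefore estimated at 40 nM, ranging from 10 nM to 200 nM.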

Compound 3, half-maximal inhibitory concentration: 15 nM
Beside the measured number, compound 3's estimate is 2.7-fold (0.43 log units) above it, and the stated range covers the measured number.
By their numbers in this assay, from the lowest: compounds 1, 2 and 3 (each within the scatter of the next).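

The change from 4-(methylsulfanyl)phenyl to 4-ethoxyphenyl in this assay gives no change at the digits printed from compound 2 to compound 3 (within the scatter) and this shows that, at this place on the aromatic ring, para to a large group, ethoxy and methylsulfanyl cannot be told apart. A sulfur link can thus give way to an oxygen link, with a slightly larger group, without a readable shift in this read-out. Nothing available explains this match. From the compounds shown here alone, whether the same place would also accept an amine, a carboxylic acid or a longer chain such as butoxy stays open.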